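Swapping Fluoro for Chloro on the Fused Ring

The source may hold more compounds than are shown below. What is called first, only, known or untested is meant among the compounds shown, and "the series" means these compounds.

Three compounds have been measured:
compound 1 `COc1cccc(-c2nc3ccccc3[nH]2)c1Cl`, 2740 nM
compound 2 `COc1cccc(-c2nc3cc(F)ccc3[nH]2)c1Cl`, 2620 nM
compound 3 `COc1ccc(-c2nc3cc(F)ccc3[nH]2)c(Cl)c1OC`, 2560 nM

All three were tested in an assay for inhibition of Alpha amylase (Homo sapiens), with a stated time of 10 min; a higher number here means a weaker inhibitor, a lower number a stronger inhibitor. The number for compound 2 lies within the scatter of both compound 1 and compound 3; the two steps recorded, a 1.0-fold lower number from compound 1 to compound 2 (0.02 log units; within the scatter) and a 1.0-fold lower number from compound 2 to compound 3 (0.01 log units; within the scatter), are both within the scatter, so nothing here has moved the read-out beyond noise.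

Compound 4 `COc1cccc(-c2nc3cc(Cl)ccc3[nH]2)c1Cl` has not yet been measured. It differs from compound 2 by one change: chloro in place of fluoro on an aromatic carbon. Among the measured compounds shown here, the step that bears most directly on this is the one from compound 1 to compound 2, where a fluoro was placed at this same site in place of hydrogen and the number barely shifted. For the measured compounds named here, no measured step tries a chloro at that site, so no firmer guide exists. The expectation is therefore a step of a 1.0-fold lower number from compound 2 to compound 4 (0.00 log units; within the scatter), that is, nothing beyond the scatter. Compound 4 is estimated at 2600 nM, with a range from 1300 nM to 5200 nM.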

Compound 4, half-maximal inhibitory concentration: 2780 nM
For compound 4 the middle estimate is 1.1-fold (0.03 log units) below the measured one; the range from low to high includes it.
By their numbers in this assay, from the lowest: compounds 3, 2, 1 and 4 (each within the scatter of the next).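

In this assay the halogen exchange gives a 1.1-fold higher number from compound 2 to compound 4 (0.03 log units; within the scatter) and chloro in place of hydrogen gives a 1.0-fold higher number from compound 1 to compound 4 (0.01 log units; within the scatter) at the same site, so both steps stay within the scatter. With hydrogen, fluoro and chloro now all tried on this aromatic carbon of the fused system, compound 1, compound 2 and compound 4 cannot be told apart, which extends the earlier fluoro result to a second halogen. No measurement here offers an explanation for this flat result.

Hydrogen and these two halogens are a narrow set, so it remains open whether an amine, a carboxylic acid or a longer alkyl chain at this site would shift the number beyond the scatter. As far as these compounds go, since all four compounds lie within the scatter of their neighbours, it is also open which changes to the shared core, if any, affect inhibition.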